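This account rests on a few compounds, and the source may have more. Where it says the series, first, only, none or still open, it means among the compounds named here.

Measured in a functional assay on MCF7 cells (Homo sapiens) for cytotoxicity, read by MTT assay, with stated times of 3 h and 24 h; a higher number here means a weaker inhibitor, a lower number a stronger inhibitor:
Compound 1 `COc1ccc(C2=[N+]3C(=Nc4c(-c5ccccc5)c5c(n4[B-]3(F)F)-c3ccc(OC)cc3CC5)C(c3ccccc3)=C2Br)cc1`: 4500 nM
Compound 2 `COc1ccc2c(c1)CCc1c(-c3ccccc3)c3n(c1-2)[B-](F)(F)[N+]1=C(c2ccc(C)cc2)C(Br)=C(c2ccccc2)C1=N3`: 8100 nM
Compound 3 `COc1ccc(C2=[N+]3C(=Nc4c(-c5ccccc5)c5c(n4[B-]3(F)F)-c3ccc(OC)cc3CC5)C(c3ccccc3)=C2I)cc1`: 140 nM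

Compound 3, at 140 nM, has the lowest of the three numbers. Compound 4 `COc1ccc2c(c1)CCc1c(-c3ccccc3)c3n(c1-2)[B-](F)(F)[N+]1=C(c2ccc(C)s2)C(I)=C(c2ccccc2)C1=N3` keeps its iodo group and differs in one place: 5-methylthiophen-2-yl in place of 4-methoxyphenyl on a carbon with a double bond to nitrogen. The large step of a 32-fold lower number from compound 1 to compound 3 (1.51 log units; beyond the scatter), iodo in place of bromo, is therefore not repeated. Among the measured compounds shown here, the closest measured step, a 1.8-fold higher number from compound 1 to compound 2 (0.26 log units; within the scatter), methyl in place of methoxy on an aromatic carbon, stays within the scatter, but no measured step exchanges the ring itself. A modest rise at most is thus expected in this assay, with wide uncertainty. The estimated change is a 1.6-fold higher number from compound 3 to compound 4 (0.20 log units; within the scatter). For compound 4 the estimated value is 220 nM, with an expected range of 60 nM to 800 nM.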

Compound 4, half-maximal inhibitory concentration: 16600 nM
The estimate for compound 4 lay 75-fold (1.88 log units) below the measured number; the whole stated range lies below it.
By their numbers in this assay, from the lowest: compound 3; then compounds 1 and 2 (each within the scatter of the next); then compound 4.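

In this assay, placing 5-methylthiophen-2-yl instead of 4-methoxyphenyl on the carbon with a double bond to nitrogen gives a 120-fold higher number from compound 3 to compound 4 (2.07 log units; beyond the scatter) as a large step. The earlier change at the far end of this aryl group, a 1.8-fold higher number from compound 1 to compound 2 (0.26 log units; within the scatter) and so within the scatter, gave no sign of this sensitivity to exchanging the ring itself. The iodo group is present in both compounds, so it alone does not secure the low number of compound 3.

From the compounds shown here alone, whether the rise belongs to the thiophene ring or to its methyl group stays open, as does the effect of a pyridine ring or a 4-aminophenyl group at this carbon. Nothing measured on these compounds gives a reason for the rise.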